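The compounds below may be only part of what the source reports. "The series", "measured", "known", "first", "only" and "open" are said of these compounds alone.

Compound 3, `COc1ccc(/C(=C\c2c[nH]c3ccc(OCc4ccccc4)cc23)C(=O)O)cc1`, gives "not determined" (no result reported) in a functional assay on A549 cells (Homo sapiens) for cytotoxicity, read by MTT assay, with a stated time of 72 h; a higher number here means a weaker inhibitor, a lower number a stronger inhibitor: its result was not determined, so it stands nowhere on the measured scale and offers no anchor of its own. Compound 4, `COc1ccc(/C(=C\c2cn(C(C)=O)c3ccc(OCc4ccccc4)cc23)C(=O)O)cc1`, differs from it by acetyl in place of hydrogen on an aromatic nitrogen. For the measured compounds named here, only two compounds carry a value, and both already bear the acetyl on that nitrogen: compound 1, `COc1cc(/C(=C\c2cn(C(C)=O)c3ccc(OCc4ccccc4)cc23)C(=O)O)cc(OC)c1OC`, gives 89100 nM in this assay, and compound 2, `CC(=O)n1cc(/C=C(/C(=O)O)c2ccc(Cl)cc2)c2cc(OCc3ccccc3)ccc21`, gives 52300 nM. Going by the values given here, the one measured step, a 1.7-fold lower number from compound 1 to compound 2 (0.23 log units; within the scatter), concerns the aryl group on the chain carbon, not the nitrogen, so it does not speak to the change from compound 3 to compound 4; it shows only that the two acetylated analogues sit close together. Among the compounds with values here, with no measured pair differing at the nitrogen, and no value for compound 3, the expectation for compound 4 rests on its likeness to compound 1 and compound 2, which it shares in the acetyl and the rest of the core while carrying a 4-methoxyphenyl. As far as these compounds go, compound 4 is therefore expected to land in the same region, with an estimated value of 70000 nM in this assay, and a range from 25000 nM to 200000 nM, the width reflecting that the change itself is untested here.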

Compound 4, half-maximal inhibitory concentration: > 100000 nM
Compound 4 was reported as a limit; the forecaster's own chance of this, stated with the estimate: 15%; at least 1.4-fold (0.15 log units) between middle value and limit.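

Compound 4 was reported only as a limit of the assay, not as a number: the limit of > 100000 nM in this assay, at which 1 of the 4 values shown sits. Set against the two acetylated analogues, it gives an at least 1.9-fold higher number from compound 2 to compound 4 (0.28 log units; that floor lies within the scatter), with methoxy in place of chloro on an aromatic carbon, and an at least 1.1-fold higher number from compound 1 to compound 4 (0.05 log units; that floor lies within the scatter), with 4-methoxyphenyl in place of 3,4,5-trimethoxyphenyl; both are floors only, so neither step separates compound 4 from the others, and the new result adds only that a third acetylated analogue gives no sign of stronger inhibition in this assay. Compound 3 has no result, so the change that matters here, acetyl in place of hydrogen on the aromatic nitrogen, still cannot be read, and this position remains without a measured comparison.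

The compounds shown leave open how a propionyl or a methyl on that aromatic nitrogen would read in this assay, and whether any such group would bring a value clear of the limit. They also leave open what a methyl ester or a primary amide in place of the carboxylic acid would give on the shared core.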